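Working notes: chloro to methoxy exchange and cytotoxicity

The compounds below may be only part of what the source reports. "The series", "measured", "known", "first", "only" and "open" are said of these compounds alone.

Compound 1 `CCOC(=O)c1c(-c2cccc(OC)c2)[nH]c2cc(OC)c(OC)cc2c1=O`, compound 2 `CCOC(=O)c1c(-c2cccc(OC)c2)[nH]c2cc(Cl)c(OC)cc2c1=O` and compound 3 `CCOC(=O)c1c(-c2cccc(-c3ccccc3)c2)[nH]c2cc(Cl)c(Cl)cc2c1=O` have been run in an ADME assay on Raji cells (Homo sapiens) for cytotoxicity, read by luminescence, with a stated time of 72 h; a lower number here means that less compound is needed, a higher number that more compound is needed for the effect. In this assay compound 1 reaches only a limit, > 21500 nM. Compound 2 likewise gives only a limit, > 21500 nM. Compound 3 too sits at a limit, > 21500 nM. Compound 2 differs from compound 1 by methoxy in place of chloro on an aromatic carbon; the step that the two limits leave unreadable from compound 2 to compound 1 stays unreadable because of the limit of > 21500 nM in this assay, at which 3 of the 3 values shown sit. Compound 3 and compound 2 differ in their cores, a difference not broken down here. Compound 4 `CCOC(=O)c1c(-c2cccc(-c3ccccc3)c2)[nH]c2cc(OC)c(Cl)cc2c1=O` is not yet measured; it differs from compound 3 by methoxy in place of chloro on an aromatic carbon. This is the same kind of change as that from compound 2 to compound 1, though around the place the exchanged group is ortho to a chloro group in compound 3 and ortho to a methoxy group in compound 2. For the measured compounds named here, since every value shown is a limit, no measured step gives a size to carry over. For compound 4 the step that the limit leaves unreadable from compound 3 to compound 4 is expected to be small. That expectation rests on the limit of compound 3, > 21500 nM, and on (the limit of > 21500 nM in this assay, at which 3 of the 3 values shown sit). Compound 4 is estimated to give 30000 nM in this assay, between 12000 nM and 100000 nM, most probably reported again only as a limit.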

Compound 4, half-maximal effective concentration: > 21500 nM
Compound 4 ended at the assay's limit; the forecaster's own chance of this, stated with the estimate: 85%; the middle value lies beyond the limit too.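

No new step can be read between compound 3 and compound 4 in this assay, because both values are limits: the limit of > 21500 nM in this assay, at which 4 of the 4 values shown sit.

The compounds shown leave open whether exchanging chloro for methoxy, or changing the core, alters cytotoxicity in this assay at all, with no compound here giving a value that is not a limit.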